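The source may report more compounds than this note shows. Statements on the series, on what has been measured and on what is new or still open speak of the compounds shown alone.

Series notes. Compound 1 `COC(=O)c1cc(-c2cccc(NC(=O)c3ccc(/C=C/C(=O)c4ccc(F)cc4F)cc3)c2)on1` carries a 2,4-difluorophenyl ketone on the shared core. In an ADME assay on Vero cells (Chlorocebus sabaeus) for cytotoxicity, read by MTT assay, with a stated time of 72 h (on this read-out higher numbers stand for lower toxicity in this test and lower numbers for higher toxicity in this test), compound 1 gives > 40 ug/mL, which is a limit of the assay rather than a number. Among the measured compounds shown here, compound 2 `COC(=O)c1cc(-c2cccc(NC(=O)c3ccc(/C=C/C(=O)c4cccnc4)cc3)c2)on1` bears a pyridin-3-yl ketone; in this assay compound 2 gives "not determined" (no result reported), so no number stands for it, and the only other value shown is the limit of > 40 ug/mL in this assay, at which 1 of the 2 values shown sits. Compound 3 `COC(=O)c1cc(-c2cccc(NC(=O)c3ccc(/C=C/C(=O)c4ccc(CC(C)C)cc4)cc3)c2)on1` differs from compound 2 by 4-isobutylphenyl in place of pyridin-3-yl on a carbonyl carbon. For the measured compounds named here, no measured step covers this change, so nothing beyond the usual scatter is assumed in either direction. Compound 3 is expected to give about 40 ug/mL in this assay, between 20 ug/mL and 80 ug/mL.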

Compound 3, half-maximal cytotoxic concentration: > 10 ug/mL
Compound 3 gave a limit, no number; the forecaster's own chance of this, stated with the estimate: 65%; the middle value is on the limit's open side.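

No step can be read from compound 1 to compound 3: in this assay both results are limits of the assay, not numbers. The compounds shown leave open whether 4-isobutylphenyl in place of 2,4-difluorophenyl on a carbonyl carbon changes the read-out at all.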